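Shortening the nitrile chain on a tetrabrominated core

This account rests on a few compounds, and the source may have more. Where it says the series, first, only, none or still open, it means among the compounds named here.

compound 1 `Cc1nc2c(Br)c(Br)c(Br)c(Br)c2n1CCC#N`: 74%
compound 2 `Cc1nc2c(Br)c(Br)c(Br)c(Br)c2n1CCCC#N`: 56%
compound 3 `N#CCCCCn1cnc2c(Br)c(Br)c(Br)c(Br)c21`: 99%

In a functional assay on MCF7 cells (Homo sapiens) for cytotoxicity, read by MTT assay, with a stated time of 24 h, tested at 20 uM (a lower number here means a stronger effect, a higher number a weaker effect of the compound at the concentration tested), compound 2 gives 56%, compound 1 gives 74% and compound 3 gives 99%. The change from compound 2 to compound 1 is cyano in place of cyanomethyl on a saturated chain carbon, two bonds along the chain from an aromatic nitrogen, and it produced a number 18 percentage points higher from compound 2 to compound 1 (beyond the scatter). The cores of compound 3 and compound 2 differ, but that difference is not broken down here. Compound 4 `N#CCCCn1cnc2c(Br)c(Br)c(Br)c(Br)c21` is not yet measured; it differs from compound 3 by cyano in place of cyanomethyl on a saturated chain carbon, three bonds along the chain from an aromatic nitrogen, the same kind of change as before, though the place is three bonds along the chain from an aromatic nitrogen rather than two. The expected step is a number 1 percentage points higher from compound 3 to compound 4 (within the scatter), smaller than the earlier one, because compound 3 already gives 99% and leaves little room upward. Compound 4 is estimated at 100%, between 88% and 112%.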

Compound 4, a percentage reported as activity, at one concentration (the size of the read-out at that concentration, not a potency): 70%
Compound 4: middle estimate off by 30 percentage points, on the high side, outside the stated range (below it).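

In this assay, the same shortening of the nitrile chain did not carry over from one core to the other, and the two steps point in opposite directions: the same change on two cores in this assay, a number 18 percentage points higher (beyond the scatter) from compound 2 to compound 1 and a number 29 percentage points lower (beyond the scatter) from compound 3 to compound 4, 47 percentage points apart, beyond the scatter of two such steps

On the core without the methyl group, the chain change gave a number 29 percentage points lower from compound 3 to compound 4 (beyond the scatter), while hydrogen in place of methyl on an aromatic carbon, with the 3-cyanopropyl chain kept, gave a number 14 percentage points higher from compound 2 to compound 4 (beyond the scatter). The outcome of this change therefore depends on the core in these two pairs, but two pairs give no rule for other cores and no reason for the difference.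

As far as these compounds go, whether an amine or a carboxylic acid in place of the nitrile, or a chain longer than 4-cyanobutyl, would follow either direction remains open.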